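Swapping a halogenated benzyl group on a dithiocarbamate series

This account rests on a few compounds, and the source may have more. Where it says the series, first, only, none or still open, it means among the compounds named here.

Three compounds share a piperazine dithiocarbamate core joined to a triazole. Compound 1 `CC(C)(C)OC(=O)N1CCN(C(=S)SCc2cn(-c3ccccc3F)nn2)CC1` gives 89600 nM in a functional assay on MCF7 cells (Homo sapiens) for inhibition, read by MTT assay, with a stated time of 72 h; on this read-out lower numbers stand for stronger inhibition and higher numbers for weaker inhibition. Compound 2 `Fc1ccc(Cn2cc(CSC(=S)N3CCNCC3)nn2)cc1` gives 49900 nM in this assay, and compound 3 `O=C(OCc1ccccc1)N1CCN(C(=S)SCc2cn(Cc3ccc(Cl)cc3)nn2)CC1` gives 27500 nM, which is the lowest of the three numbers, beyond the scatter from compound 1 but within it of compound 2. Compound 4 `O=C(OCc1ccccc1)N1CCN(C(=S)SCc2cn(Cc3ccccc3F)nn2)CC1` differs from compound 3 by one exchange: 2-fluorophenyl in place of 4-chlorophenyl on a saturated chain carbon bound to an aromatic nitrogen. Among the measured compounds shown here, no measured pair shows this exact change, so only a modest shift is expected, with no clear direction beyond the scatter. Compound 4 is therefore estimated at 35000 nM, within a range from 12000 nM to 100000 nM, which means an expected step of a 1.3-fold higher number from compound 3 to compound 4 (0.10 log units; within the scatter).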

Compound 4, half-maximal inhibitory concentration: 7950 nM
Compound 4: the middle estimate sits 4.4-fold (0.64 log units) above what was measured, and the stated range ends above it.
By their numbers in this assay, from the lowest: compound 4; then compounds 3, 2 and 1 (each within the scatter of the next, the first and the last beyond it).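

In this assay, 2-fluorophenyl in place of 4-chlorophenyl on a saturated chain carbon bound to an aromatic nitrogen gives a 3.5-fold lower number from compound 3 to compound 4 (0.54 log units; beyond the scatter) and this step lies beyond the scatter. Among the compounds shown here, this is the first one-place comparison, and it shows that the number responds to this group alone, with the rest of the molecule unchanged. Nothing measured here gives a reason for the step. The halogen and its place on the ring change together, so their shares cannot be separated. On these data alone, how a 2-chlorobenzyl or an unsubstituted benzyl group would read here stays open.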